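The source may hold more compounds than are shown below. What is called first, only, known or untested is meant among the compounds shown, and "the series" means these compounds.

Measured compounds:
compound 1 `CCOc1ccc(NC(=O)Nc2cccc(CNc3nccnc3Cl)c2)cc1`, 7240 nM
compound 2 `O=C(Nc1cccc(CNc2nccnc2Cl)c1)NC1CCCCC1`, a limit of the assay, > 40000 nM
compound 3 `Cc1ccccc1NC(=O)Nc1cccc(CNc2nccnc2Cl)c1`, 14000 nM

In a functional assay on MGC-803 cells (Homo sapiens) for antiproliferative activity, read by MTT assay, with a stated time of 48 h (a higher number here means a weaker inhibitor, a lower number a stronger inhibitor), compound 1 gives 7240 nM. Compound 2 sits at a limit of the assay, > 40000 nM. Compound 3 gives 14000 nM, the higher of the two numbers, though a 1.9-fold higher number from compound 1 to compound 3 (0.29 log units; within the scatter) is within the scatter. The measured steps all change the group on the amide-type nitrogen: an at least 5.5-fold higher number from compound 1 to compound 2 (0.74 log units; beyond the scatter) and an at least 2.8-fold lower number from compound 2 to compound 3 (0.45 log units; beyond the scatter), both beyond the scatter, and the aryl-to-aryl swap a 1.9-fold higher number from compound 1 to compound 3 (0.29 log units; within the scatter), within it.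

Compound 4 `COc1ccccc1NC(=O)Nc1cccc(CNc2nccnc2Cl)c1` differs from compound 3 by methoxy in place of methyl on an aromatic carbon. Within the data shown here, no measured step exchanges methyl for methoxy; the closest guide is the aryl-to-aryl swap a 1.9-fold higher number from compound 1 to compound 3 (0.29 log units; within the scatter), which stayed within the scatter. The expected step is therefore small, a 1.4-fold lower number from compound 3 to compound 4 (0.15 log units; within the scatter), with no confident direction. Compound 4 is estimated at 10000 nM, range 4000 nM to 30000 nM.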

Compound 4, half-maximal inhibitory concentration: 12200 nM
The estimate for compound 4 lay 1.2-fold (0.09 log units) below the measured number; measured number inside the range.
By their numbers in this assay, from the lowest: compounds 1, 4 and 3 (each within the scatter of the next). At a limit, above all of these: compound 2.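

On the aromatic carbon ortho to a large group, methoxy and methyl are not separated: a 1.1-fold lower number from compound 3 to compound 4 (0.06 log units; within the scatter). The comparison of 2-methoxyphenyl with 4-ethoxyphenyl also stays within the scatter, a 1.7-fold higher number from compound 1 to compound 4 (0.23 log units; within the scatter), so compound 1, compound 3 and compound 4 cannot be ranked. A second aryl group now stands clear of cyclohexyl, an at least 3.2-fold lower number from compound 2 to compound 4 (0.51 log units; beyond the scatter), and the value of compound 2 in that step is a limit, not a number: the limit of > 40000 nM in this assay, at which 1 of the 4 values shown sits.

Going by these compounds, whether an amine or a carboxylic acid at this ortho place would move the number remains open. So does whether a longer alkoxy chain there would separate from methoxy.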